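From phenyl to 4-hydroxyphenyl in compound 3

The source may hold more compounds than are shown below. What is called first, only, known or untested is meant among the compounds shown, and "the series" means these compounds.

In a functional assay on A2780 cells (Homo sapiens) for inhibition, read by sulforhodamine B assay (on this read-out lower numbers stand for stronger inhibition of growth and higher numbers for weaker inhibition of growth), compound 3 (`Cc1ccc2[nH]c(-c3ccc(-c4ccc(-c5ccccc5)cc4)cc3)nc2c1`) gives 41200 nM. That value lies within the scatter of compound 2 (`Oc1ccc(-c2ccc(-c3ccc(-c4nc5ccccc5[nH]4)cc3)cc2)cc1`) at 36000 nM, while compound 1 (`Cc1ccc2[nH]c(-c3ccc(-c4ccc(-c5cccc(Cl)c5)cc4)cc3)nc2c1`) stands clearly lower at 2800 nM.

The next change leads to compound 4 (`Cc1ccc2[nH]c(-c3ccc(-c4ccc(-c5ccc(O)cc5)cc4)cc3)nc2c1`): hydroxy in place of hydrogen on an aromatic carbon, para to a large group (hydroxy in place of hydrogen on an aromatic carbon). For the measured compounds named here, only one measured step involves a single substituent, a 15-fold higher number from compound 1 to compound 3 (1.17 log units; beyond the scatter), with hydrogen in place of chloro. It is large, but it concerns chloro and not hydroxy, so it supports the direction only loosely. Compound 3 carries a methyl group that the hydroxy-bearing compound 2 lacks, and compound 2 gives 36000 nM in this assay, which argues against a large gain.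

A modest move towards a lower number is therefore expected, smaller than the chloro step, and it may not clear the scatter: a 2.7-fold lower number from compound 3 to compound 4 (0.44 log units; beyond the scatter). For compound 4 the estimated value is 15000 nM, with an expected range of 4000 nM to 45000 nM.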

Compound 4, concentration for 50% growth inhibition: 31200 nM
For compound 4 the middle estimate is 2.1-fold (0.32 log units) below the measured one; low and high end bracket the measured number.
By their numbers in this assay, from the lowest: compound 1; then compounds 4, 2 and 3 (each within the scatter of the next).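

In this assay, hydroxy in place of hydrogen on an aromatic carbon, para to a large group, gives no change beyond the scatter, with a 1.3-fold lower number from compound 3 to compound 4 (0.12 log units; within the scatter). Methyl in place of hydrogen among the hydroxy-bearing compounds is equally unreadable, with a 1.2-fold lower number from compound 2 to compound 4 (0.06 log units; within the scatter), whereas 4-hydroxyphenyl does not match 3-chlorophenyl, with an 11-fold higher number from compound 1 to compound 4 (1.05 log units; beyond the scatter), so among these compounds only the 3-chlorophenyl group stands apart. No supporting data bear on the reason for these results.

As far as these compounds go, whether an amine or a carboxylic acid at this para position would stay level with hydrogen and hydroxy remains open. The compounds shown also cannot separate the contribution of chloro itself from that of its place on the ring, since no 4-chlorophenyl analogue is among them.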